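Working notes on a four-compound cytotoxicity series

This account rests on a few compounds, and the source may have more. Where it says the series, first, only, none or still open, it means among the compounds named here.

Measured so far:
- compound 1 `O=C(/C=C/c1ccc(OCCCCCO[N+](=O)[O-])c(O)c1)OCCCCCO[N+](=O)[O-]`: > 50000 nM
- compound 2 `O=C(/C=C/c1ccc(OCCCCO[N+](=O)[O-])c(O)c1)OCCCCO[N+](=O)[O-]`: > 50000 nM
- compound 3 `COc1cc(/C=C/C(=O)OCCCCCO[N+](=O)[O-])ccc1OCCCCCO[N+](=O)[O-]`: > 50000 nM

In a functional assay on M14 cells (Homo sapiens) for cytotoxicity, read by resazurin assay, with a stated time of 72 h (a higher number here means a weaker inhibitor, a lower number a stronger inhibitor), compound 1 returns only a limit, > 50000 nM. In this assay compound 2 likewise returns only a limit, > 50000 nM. For compound 3 this assay again gives a limit, > 50000 nM. Among the compounds with values here, the one change that can be traced within the measured set is methyl in place of hydrogen on an oxygen on an aromatic ring, and its size is a step that the two limits leave unreadable from compound 1 to compound 3 because of the limit of > 50000 nM in this assay, at which 3 of the 3 values shown sit. The difference between the core of compound 1 and the core of compound 2 is not broken down here.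

Compound 4 `COc1cc(/C=C/C(=O)OCCCCO[N+](=O)[O-])ccc1OCCCCO[N+](=O)[O-]` is not yet measured. Within the data shown here, it differs from compound 2 by methyl in place of hydrogen on an oxygen on an aromatic ring, the same change as the one from compound 1 to compound 3, with the same surroundings at the place of the change. Since the measured pair leaves that step unreadable, the expectation for compound 4 rests only on the limits returned for compound 1 and compound 2, and on the unreadable step from compound 1 to compound 3. The step from compound 2 to compound 4 in this assay is expected to be a step that the limit leaves unreadable from compound 2 to compound 4. Compound 4 is estimated at 80000 nM, within 35000 nM to 200000 nM, with the assay most likely to report only a limit once more.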

Compound 4, half-maximal inhibitory concentration: > 50000 nM
Compound 4 was reported as a limit (the forecaster's own chance of this, stated with the estimate: 85%); the middle value does not contradict the limit.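

No new step can be read in this assay: compound 4, like compound 2, returns only a limit, so the change from hydroxy to methoxy stays unreadable between them, as it does between compound 1 and compound 3, for the following reason: the limit of > 50000 nM in this assay, at which 4 of the 4 values shown sit.

The compounds shown leave open whether hydroxy to methoxy, or the difference between the core of compound 1 and the core of compound 2, alters the read-out at all.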